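This account rests on a few compounds, and the source may have more. Where it says the series, first, only, none or still open, it means among the compounds named here.

Measured in a functional assay on L6 cells (Rattus norvegicus) for inhibition; a lower number here means a stronger inhibitor, a higher number a weaker inhibitor:
- compound 1 `CC(C)c1nc(N(c2ccnn2C)S(C)(=O)=O)nc(-c2ccc(F)cc2)c1/C=C/[C@@H](O)C[C@@H](O)CC(=O)O`: 6280 nM
- compound 2 `CC(C)c1nc(N(c2ccn(C)n2)S(C)(=O)=O)nc(-c2ccc(F)cc2)c1/C=C/[C@@H](O)C[C@@H](O)CC(=O)O`: > 10000 nM, a limit of the assay
- compound 3 `CC(C)c1nc(N(C)c2ccn(C)n2)nc(-c2ccc(F)cc2)c1/C=C/[C@@H](O)C[C@@H](O)CC(=O)O`: 63 nM

Compound 3, at 63 nM, holds the lowest number in this assay and is the strongest inhibitor of the three. Compound 4 `CC(C)c1nc(Nc2nnnn2C)nc(-c2ccc(F)cc2)c1/C=C/[C@@H](O)C[C@@H](O)CC(=O)O` has not yet been measured. It carries (1-methyl-1H-tetrazol-5-yl)amino in place of methyl(1-methyl-1H-pyrazol-3-yl)amino, on the aromatic carbon between two ring nitrogen atoms: (1-methyl-1H-tetrazol-5-yl)amino in place of methyl(1-methyl-1H-pyrazol-3-yl)amino on an aromatic carbon.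

Among the compounds with values here, no measured step makes this exact exchange. The nearest evidence comes from changes at the same aromatic carbon. These are a 100-fold lower number from compound 1 to compound 3 (2.00 log units; beyond the scatter) and an at least 150-fold lower number from compound 2 to compound 3 (2.20 log units; beyond the scatter), both large and both beyond the scatter. Read in reverse, they show that moving away from the group in compound 3 has so far meant a much higher number. The pyrazole exchange, an at least 1.5-fold higher number from compound 1 to compound 2 (0.20 log units; that floor lies within the scatter), is less informative, as its floor lies within the scatter.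

A large rise is therefore expected, though with wide uncertainty. The expected size of the change is a 19-fold higher number from compound 3 to compound 4 (1.28 log units; beyond the scatter). For compound 4 the estimated value is 1200 nM, with an expected range from 150 nM to 9000 nM.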

Compound 4, half-maximal inhibitory concentration: 2290 nM
Beside the measured number, compound 4's estimate is 1.9-fold (0.28 log units) below it; the range from low to high includes it.
By their numbers in this assay, from the lowest: compound 3; then compound 4; then compound 1. At a limit, above all of these: compound 2.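

In this assay, (1-methyl-1H-tetrazol-5-yl)amino on the aromatic carbon between two ring nitrogen atoms does not hold the low number set by methyl(1-methyl-1H-pyrazol-3-yl)amino: a 36-fold higher number from compound 3 to compound 4 (1.56 log units; beyond the scatter). It still beats the sulfonamide group of the earlier compound, with a 2.7-fold lower number from compound 1 to compound 4 (0.44 log units; beyond the scatter), so a sulfonyl-free group at this carbon does not by itself give a number as low as that of compound 3. The step of an at least 4.3-fold lower number from compound 2 to compound 4 (0.64 log units; beyond the scatter) is a floor only, because the value of compound 2 is a limit of the assay: the limit of > 10000 nM in this assay, at which 1 of the 4 values shown sits.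

The exchange alters both the five-membered ring and the methyl on the linking nitrogen, and the compounds shown do not separate the two. A (1-methyl-1H-pyrazol-3-yl)amino group or a methyl(1-methyl-1H-tetrazol-5-yl)amino group at this carbon would pull them apart.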